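Phenyl in place of methoxy: working notes

A few compounds are considered here, and "the series" means these few. Any claim that something is new, unique, unknown or untested is made for them only; others in the source may bear on it.

Measured in an ADME assay on L929 cells (Mus musculus) for cytotoxicity, read by resazurin assay, with a stated time of 96 h (a lower number here means that less compound is tolerated, a higher number that more compound is tolerated), so far:
- compound 1 `COc1ccc(/C(COc2ccc(Br)cc2)=N\NC(N)=S)cc1` gives < 25400 nM as a limit
- compound 2 `NC(=S)N/N=C(/COc1ccc(Br)cc1)c1ccc(F)cc1` gives < 26200 nM as a limit

Compound 1 has no number to stand on in this assay and is held only by its limit (< 25400 nM). Compound 2 is likewise held only by a limit (< 26200 nM).

Compound 3 `NC(=S)N/N=C(/COc1ccc(Br)cc1)c1ccc(-c2ccccc2)cc1` is the next to be read. The change is phenyl in place of methoxy on an aromatic carbon and amounts to phenyl in place of methoxy on an aromatic carbon, para to a large group.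

Among the compounds with values here, the one measured step that also removes the methoxy is a step that the two limits leave unreadable from compound 1 to compound 2 and so gives no size to carry over. Within the data shown here, the data hold no measured step that brings in a phenyl. With compound 1 known only through its limit (< 25400 nM), no step beyond the usual scatter is expected in this assay, and no direction can be argued from a measured size. A report of compound 3 as a limit again would be no surprise.

The expected step is a step that the limit leaves unreadable from compound 1 to compound 3 and remains an estimate. For compound 3 the estimated value is 15000 nM with an expected range from 6000 nM to 24000 nM in this assay.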

Compound 3, half-maximal cytotoxic concentration: 22700 nM
Beside the measured number, compound 3's estimate is 1.5-fold (0.18 log units) below it; low and high end bracket the measured number.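

In this assay, within the data shown here, neither the step to compound 3 from compound 1 nor the one from compound 2 can be read, because compound 1 is held only by a limit: the limit of < 25400 nM in this assay, at which 1 of the 3 values shown sits.

Compound 2 is likewise held only by a limit: the limit of < 26200 nM in this assay, at which 1 of the 3 values shown sits.

The compounds shown leave open whether phenyl in place of methoxy or fluoro shifts tolerance at all.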